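Methyl on the ring carbon: two placements compared

A few compounds are considered here, and "the series" means these few. Any claim that something is new, unique, unknown or untested is made for them only; others in the source may bear on it.

Three compounds of the series are measured in a functional assay on HeLa cells (Homo sapiens) for cytotoxicity, read by MTT assay, with a stated time of 72 h; a higher number here means a weaker inhibitor, a lower number a stronger inhibitor. Compound 1 `N/C(=N\NC(=S)N1CCCCCC1)c1ccccn1` gives 6000 nM. Compound 3 `N/C(=N\NC(=S)N1CCSCC1)c1ccccn1` gives 7800 nM, and compound 2 `Cc1ccnc(/C(N)=N/NC(=S)N2CCSCC2)c1` gives 15500 nM. The difference between the core of compound 1 and the core of compound 3 is not broken down here. From compound 3 to compound 2 the change is methyl in place of hydrogen on an aromatic carbon, and it gave a 2.0-fold higher number from compound 3 to compound 2 (0.30 log units; within the scatter).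

Compound 4 `Cc1cccc(/C(N)=N/NC(=S)N2CCCCCC2)n1` is not yet measured. It differs from compound 1 by methyl in place of hydrogen on an aromatic carbon. This is the same kind of change as that from compound 3 to compound 2, but not the same: in compound 4 the methyl sits next to the ring nitrogen, meta to a large group, whereas in compound 2 it sits meta to a large group and opposite the ring nitrogen. Among the measured compounds shown here, the single precedent is a step within the scatter, so the expectation is weak and drawn from it alone. In this assay the expected step is a 1.7-fold higher number from compound 1 to compound 4 (0.22 log units; within the scatter), resting on a 2.0-fold higher number from compound 3 to compound 2 (0.30 log units; within the scatter). Compound 4 is therefore estimated at 10000 nM in this assay, with a likely range from 4000 nM to 25000 nM.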

Compound 4, half-maximal inhibitory concentration: 1000 nM
Beside the measured number, compound 4's estimate is 10-fold (1.00 log units) above it, and the stated range ends above it.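

In this assay, methyl in place of hydrogen on an aromatic carbon gives a 6.0-fold lower number from compound 1 to compound 4 (0.78 log units; beyond the scatter), so in this series the change does not carry from one core to another with a fixed size or direction: the same change on two cores in this assay, a 2.0-fold higher number (0.30 log units; within the scatter) from compound 3 to compound 2 and a 6.0-fold lower number (0.78 log units; beyond the scatter) from compound 1 to compound 4, 12-fold (1.08 log units) apart, beyond the scatter of two such steps This does not show that the core alone sets the outcome, as the two pairs also differ in where the methyl sits: in compound 4 it is next to the ring nitrogen, a placement that compound 2 does not share. With one pair on each core, the effects of core and placement cannot be separated, and the data give no cause for the gap between the steps.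

The compounds shown leave open whether methyl next to the ring nitrogen would also lower the number on the core of compound 3, and what the placement in compound 2 would do on the core of compound 1. They also leave open whether an ethyl, a methoxy or a chlorine in the place of the methyl in compound 4 would give a step of similar size.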